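The compounds below may be only part of what the source reports. "The series", "measured", "known", "first", "only" and "open" are said of these compounds alone.

Measured compounds:
- compound 1, `O=C1C(Nc2ccc(Br)cc2)=CC(=O)c2c1nc1n2[C@H]2OC[C@@H](O)[C@H]2OC1`: 2020 nM
- compound 2, `CCc1ccc(NC2=CC(=O)c3nc4n(c3C2=O)[C@H]2OC[C@@H](O)[C@H]2OC4)cc1`: 1290 nM
- compound 3, `O=C1C(N2CCCC2)=CC(=O)c2c1nc1n2[C@H]2OC[C@@H](O)[C@H]2OC1`: > 16000 nM, which is a limit of the assay rather than a number

All three were tested in a functional assay on MGC-803 cells (Homo sapiens) for inhibition, read by sulforhodamine B assay; on this read-out lower numbers stand for stronger inhibition and higher numbers for weaker inhibition. Compound 2 gives the lowest of the two real numbers, and compound 1 is its nearest neighbour; the gap between them lies within the scatter, so no order can be read from it. For compound 3 only a limit of the assay was obtained. One single-point step is known: an at least 7.9-fold higher number from compound 1 to compound 3 (0.89 log units; beyond the scatter), a weakening that runs up to the limit of > 16000 nM in this assay, at which 1 of the 3 values shown sits.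

Compound 4, `O=C1C=C(Nc2cccc(Cl)c2)C(=O)c2c1nc1n2[C@H]2OC[C@@H](O)[C@H]2OC1`, differs from compound 2 in one place: 3-chlorophenyl in place of 4-ethylphenyl on an amine nitrogen. Among the measured compounds shown here, the only measured step replaced the whole arylamino group with pyrrolidin-1-yl, a far larger change than the one here, where an arylamino group remains and only the ring substituent changes. Compound 1 and compound 2 each carry a substituted phenyl on that nitrogen and sit within the scatter of each other. Against compound 2 the expected step is therefore a 1.6-fold higher number from compound 2 to compound 4 (0.19 log units; within the scatter), within the scatter. For compound 4 the estimated value is 2000 nM, with a range from 800 nM to 5000 nM.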

Compound 4, half-maximal inhibitory concentration: 1770 nM
Estimate against measurement, compound 4: 1.1-fold (0.05 log units) above; measured number inside the range.
By their numbers in this assay, from the lowest: compounds 2, 4 and 1 (each within the scatter of the next). At a limit, above all of these: compound 3.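

In this assay, exchanging 4-ethylphenyl for 3-chlorophenyl on the amine nitrogen gives a 1.4-fold higher number from compound 2 to compound 4 (0.14 log units; within the scatter), so no order can be read between these two compounds. This is the first step shown that keeps a substituted phenyl on that nitrogen and alters only the phenyl's substituent, whereas the earlier step removed the whole arylamino group and gave an at least 7.9-fold higher number from compound 1 to compound 3 (0.89 log units; beyond the scatter). Within this single pair, the exchange of ethyl at the 4 position for chlorine at the 3 position leaves the number within the scatter, and nothing measured here offers a cause for that result.

Because the identity of the substituent and its place on the ring changed together, this pair cannot separate the two, and 4-chlorophenyl and 3-ethylphenyl would be needed to pull them apart. From the compounds shown here alone, it also remains open whether the phenyl ring itself matters on this nitrogen, a question that an unsubstituted phenyl, a benzyl group or a simple open-chain amine such as methylamino could address.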